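A few compounds are considered here, and "the series" means these few. Any claim that something is new, unique, unknown or untested is made for them only; others in the source may bear on it.

For the measured compounds named here, compound 1 `COc1cc(OC)c(Cl)c(-c2ccc3c(NC(=O)c4ccc(N5CCN(C6CCC6)CC5)cc4)n[nH]c3n2)c1Cl` holds the only number in a functional assay on NCI-H1581 cells (Homo sapiens) for antiproliferative activity, read by CCK-8 assay, with a stated time of 72 h (a higher number here means a weaker inhibitor, a lower number a stronger inhibitor), where compound 1 gives 2.3 nM. Compound 2 `COc1cc(OC)cc(-c2ccc3c(NC(=O)c4ccc(N5CCN(C)CC5)cc4)n[nH]c3n2)c1` in this assay reaches only the limit > 1000 nM; that is the limit of > 1000 nM in this assay, at which 1 of the 2 values shown sits. Compound 3 `COc1cc(OC)c(Cl)c(-c2ccc3c(NC(=O)c4ccc(N5CCNCC5)cc4)n[nH]c3n2)c1Cl` differs from compound 1 by hydrogen in place of cyclobutyl on an amine nitrogen in a ring. Going by the values given here, no measured pair isolates that change, so its size is unknown from the data. The expected step of a 2.2-fold higher number from compound 1 to compound 3 (0.34 log units; beyond the scatter) in this assay is small, if anything toward weaker inhibition, and probably within the scatter. Compound 3 is therefore estimated at 5 nM, with a range of 1.5 nM to 20 nM.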

Compound 3, half-maximal inhibitory concentration: 1.4 nM
The estimate for compound 3 lay 3.6-fold (0.55 log units) above the measured number, and the stated range ends above it.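

Hydrogen in place of cyclobutyl on the amine nitrogen in the ring can now be read as a matched pair: in this assay the result is a 1.6-fold lower number from compound 1 to compound 3 (0.22 log units; within the scatter). The assay therefore does not separate 4-cyclobutylpiperazin-1-yl from piperazin-1-yl at this position. No measurement shown gives a cause for this.

Compound 2 gives only a limit, > 1000 nM, and differs from compound 1 in more than one place, so it does not inform this nitrogen. Open, going by these compounds, is whether an acetyl group or a longer chain ending in an amine would be tolerated on this nitrogen.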